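Opening a ring into a hydroxylated chain

A few compounds are considered here, and "the series" means these few. Any claim that something is new, unique, unknown or untested is made for them only; others in the source may bear on it.

Three compounds share a common core and were tested in an ADME assay on A549 cells (Homo sapiens) for cytotoxicity, read by resazurin assay, with a stated time of 48 h; a lower number here means that less compound is tolerated, a higher number that more compound is tolerated. Compound 1 `CCCCCCCCC(C)Nc1ccc(NC(=O)c2cc(Cl)ccc2O)c(Cl)c1` gives 21900 nM. Compound 2 `CC1(Nc2ccc(NC(=O)c3cc(Cl)ccc3O)c(Cl)c2)CCCC1` gives 157000 nM, the highest number of the three, so compound 2 is the one tolerated best by these cells. Compound 3 `CC1(ON(c2ccc(NC(=O)c3cc(Cl)ccc3O)c(Cl)c2)C2(C)CCCC2)CCCC1` gives 18000 nM. For the measured compounds named here, the only pair differing in a single place is compound 2 and compound 3, where a (1-methylcyclopentyl)oxy group in place of hydrogen on a nitrogen on an aromatic ring gives an 8.7-fold lower number from compound 2 to compound 3 (0.94 log units; beyond the scatter).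

Compound 4 `CC(C)(CCO)Nc1ccc(NC(=O)c2cc(Cl)ccc2O)c(Cl)c1` has not yet been measured. Relative to compound 2 the change is 3-hydroxy-1,1-dimethylpropyl in place of 1-methylcyclopentyl on a nitrogen on an aromatic ring: a ring leaves and an open chain with a hydroxyl group enters, on the same nitrogen.

Going by the values given here, no measured step bears directly on this change. Among the compounds with values here, the one measured step, from compound 2 to compound 3, alters the nitrogen in a different way, and compound 1 differs from compound 2 in more than one place. With no guide from the data, the estimate for compound 4 in this assay is 70000 nM, with a range from 20000 nM to 200000 nM, which would mean an expected step of a 2.2-fold lower number from compound 2 to compound 4 (0.35 log units; beyond the scatter), set wide enough to allow a move either way.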

Compound 4, half-maximal cytotoxic concentration: 170000 nM
Compound 4: middle estimate off by 2.4-fold (0.39 log units), on the low side, and the stated range covers the measured number.
By their numbers in this assay, from the lowest: compounds 3 and 1 (each within the scatter of the next); then compounds 2 and 4 (each within the scatter of the next).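

In this assay, putting 3-hydroxy-1,1-dimethylpropyl in place of 1-methylcyclopentyl on the nitrogen gives a 1.1-fold higher number from compound 2 to compound 4 (0.03 log units; within the scatter), so the two compounds cannot be told apart here. For the compounds shown here, this is the first sign that this substituent on the nitrogen can lose its ring and gain a hydroxyl group, with a hydrogen-bond donor and a hydrogen-bond acceptor that the ring lacks, without a measurable difference in how well the cells tolerate the compound, whereas the other change at this nitrogen gives an 8.7-fold lower number from compound 2 to compound 3 (0.94 log units; beyond the scatter). Nothing available explains why this exchange leaves the reading within the scatter.

Since the ring and the hydroxyl group are exchanged in one step, the two changes cannot be separated here, and a 1,1-dimethylbutyl chain, open like that of compound 4 but carrying no hydroxyl group, would be needed to tell them apart. On these data alone, it also remains open whether this assay would read the same with an amine or a carboxylic acid at the end of the chain in place of the hydroxyl group, or with a longer chain.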